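Homologation of the ring substituent on the imidazole

The compounds below may be only part of what the source reports. "The series", "measured", "known", "first", "only" and "open" are said of these compounds alone.

Of the compounds shown here, two have been measured in an in vitro functional assay on cells for agonist activity at Bombesin receptor subtype-3 (Homo sapiens), read by luminescence and calcium flux; a higher number here means that more compound is needed for the effect, a lower number that less compound is needed. Compound 1, `CCCCc1cnc(C(C)Cc2ccc(-c3ccccc3C(=O)O)cc2)[nH]1`, gives 2760 nM in this assay. Compound 2, `O=C(O)c1ccccc1-c1ccc(CCc2ncc(CC3CCCC3)[nH]2)cc1`, gives 133 nM in this assay, the lowest of the two numbers and a gap to compound 1 that lies beyond the scatter. Compound 3, `O=C(O)c1ccccc1-c1ccc(CCc2ncc(CCC3CCCCC3)[nH]2)cc1`, is not yet measured; it differs from compound 2 in one place: cyclohexylmethyl in place of cyclopentyl on a saturated chain carbon bound to an aromatic carbon. Within the data shown here, no step between measured compounds isolates this change, so the expectation rests on the two values alone. Compound 2 is taken as the anchor, and the step of a 1.4-fold higher number from compound 2 to compound 3 (0.13 log units; within the scatter) is expected to stay within the scatter, with a small lean towards a higher number rather than a lower one. Compound 3 is therefore estimated at 180 nM in this assay, in a range from 60 nM to 550 nM.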

Compound 3, half-maximal effective concentration: 642 nM
Compound 3: middle estimate off by 3.6-fold (0.55 log units), on the low side; the measured number lies above the stated range.
By their numbers in this assay, from the lowest: compound 2; then compound 3; then compound 1.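

In this assay, among these compounds, this is the first step that isolates the group on this position, and it reads a 4.8-fold higher number from compound 2 to compound 3 (0.68 log units; beyond the scatter). Replacing cyclopentyl with cyclohexylmethyl on a saturated chain carbon bound to an aromatic carbon is therefore not a neutral change, even though both groups are carbon only, with no hydrogen-bond donors or acceptors and no net charge. No measurement available here bears on the reason for this step.

The change enlarges the ring and lengthens the chain together, so the compounds shown do not separate the two; a 2-cyclopentylethyl group in place of cyclopentylmethyl would keep the five-membered ring on the longer chain. Also open, on these data alone, is how this position responds to a group that is not all carbon, such as an amine at the end of the chain.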